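Trimethoxyphenyl pyrazole chalcones: dichlorophenyl analogue at one concentration

This account rests on a few compounds, and the source may have more. Where it says the series, first, only, none or still open, it means among the compounds named here.

Measured so far:
- compound 1, `COc1cc(-c2cc(/C=C/C(=O)c3ccc(N)cc3)[nH]n2)cc(OC)c1OC`: 99%
- compound 2, `COc1ccc(-c2cc(/C=C/C(=O)c3ccc(OC)c(OC)c3)[nH]n2)cc1`: 93%

Both values come from a functional assay on SN12C cells (Homo sapiens) for cytotoxicity, read by sulforhodamine B assay, with a stated time of 48 h, tested at 0.1 uM; on this read-out higher numbers stand for a weaker effect at the one concentration tested and lower numbers for a stronger effect. At the single concentration used, compound 1 gives 99% and compound 2 gives 93%; the two numbers lie within the scatter of each other, so nothing separates compound 1 from compound 2, and neither shows a marked effect.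

Compound 3, `COc1cc(-c2cc(/C=C/C(=O)c3ccc(Cl)c(Cl)c3)[nH]n2)cc(OC)c1OC`, has not yet been measured. It differs from compound 1 in one place: 3,4-dichlorophenyl in place of 4-aminophenyl on a carbonyl carbon. Within the data shown here, no step between measured compounds tells how this assay answers a change at the carbonyl-bound ring, so the expectation rests only on the two numbers above, which sit close to no effect.

The step expected is a number 4 percentage points lower from compound 1 to compound 3 (within the scatter), none beyond the scatter. Compound 3 is estimated at 95%, within 82% to 104%.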

Compound 3, a percentage reported as activity, at one concentration (the size of the read-out at that concentration, not a potency): 96%
Estimate against measurement, compound 3: 1 percentage points below, and the stated range covers the measured number.
By their numbers in this assay, from the lowest: compounds 2, 3 and 1 (each within the scatter of the next).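

In this assay the position on the carbonyl carbon now has its first one-place step: 3,4-dichlorophenyl in place of 4-aminophenyl gives a number 3 percentage points lower from compound 1 to compound 3 (within the scatter) at the single concentration tested. The exchange removes the hydrogen-bond donor and acceptor of 4-aminophenyl and brings in chlorine, yet the read-out does not separate the two compounds, and neither compound shows a marked effect at this concentration. No measured property on hand accounts for this outcome.

As far as these compounds go, whether any group at this position can move the read-out away from near no effect remains open; a carboxylic acid or a morpholine on this aromatic ring would test that. Also open, from the compounds shown here alone, is whether the same flat picture holds at a higher concentration, where differences between these compounds might appear.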